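Benzoyl to oxime on the thioether chain of compound 2

A few compounds are considered here, and "the series" means these few. Any claim that something is new, unique, unknown or untested is made for them only; others in the source may bear on it.

Measured so far in a functional assay on the whole organism (strain albino) for inhibition, with Rattus norvegicus as the target, read by paw edema, with a stated time of 1 h, at a dose of 0.28 mmol/kg by the oral route; a lower number here means less inhibition, a higher number more inhibition at the dose given (going by the name of the read-out):
compound 1 `C=CCn1c(SCC(=O)c2ccccc2)nnc1-c1ccc(OC)cc1`: 49%
compound 2 `CCn1c(SCC(=O)c2ccccc2)nnc1-c1cc(OC)c(OC)c(OC)c1`: 29%

Compound 2 holds the lower of the two numbers. Its nearest neighbour is compound 1, which sits higher by a margin beyond the usual scatter of this assay, so the two compounds are told apart by the measurement itself. Within the data shown here, no pair of measured compounds differs in only one place, so no single step has been read so far.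

Compound 3 `CCn1c(SC/C(=N/O)c2ccccc2)nnc1-c1cc(OC)c(OC)c(OC)c1` is the next compound to be tested. It differs from compound 2 at one position: a group of 9 heavy atoms (7 carbon, 1 nitrogen, 1 oxygen; one six-membered aromatic ring of carbon only) in place of a group of 8 heavy atoms (7 carbon, 1 oxygen; one six-membered aromatic ring of carbon only), on a saturated chain carbon bound to a sulfur

Among the measured compounds shown here, nothing among the measured compounds shows how this particular exchange affects the read-out, so the expectation rests on the value of compound 2 alone and on the fact that the exchanged groups are close in size and in ring content. The step is therefore expected to be small, a number 6 percentage points higher from compound 2 to compound 3 (within the scatter), with no clear direction beyond the scatter.

Compound 3 is estimated to give 35%, with a range from 15% to 55%.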

Compound 3, a percentage reported as inhibition, in the whole organism at one dose (the size of the read-out at that dose, not a potency): 63%
Estimate against measurement, compound 3: 28 percentage points below; measured number outside the range, above it.
By their numbers in this assay, from the lowest: compound 2; then compound 1; then compound 3.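

In this assay, replacing the benzoyl group with the oxime on a saturated chain carbon bound to a sulfur gives a number 34 percentage points higher from compound 2 to compound 3 (beyond the scatter). Among these compounds, this is the first single change that can be read, and it shows that the read-out responds strongly to an edit at this position, even though the aromatic ring and the double bond outside aromatic rings both stay in the counted group, which gains a nitrogen, 1 hydrogen-bond donor where benzoyl has 0, and 2 hydrogen-bond acceptors where benzoyl has 1. Nothing available ties the rise to any one of these differences.

On these data alone, whether the step depends on the hydrogen of the oxime remains open, and an oxime methyl ether or a secondary alcohol in place of the carbonyl would help to separate the oxime's parts. As far as these compounds go, it is also open whether the same exchange gives a comparable step on the core of compound 1, since this result rests on a single pair of compounds at one dose and one time.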